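Aryl swap on the piperazine nitrogen of the diphenylacetamide series

The source may report more compounds than this note shows. Statements on the series, on what has been measured and on what is new or still open speak of the compounds shown alone.

Compound 2 `COc1ccccc1N1CCN(CC(=O)N(c2ccccc2)c2ccccc2)CC1` gives 12.7 mg/kg in a functional assay on the whole organism (strain Swiss albino) for inhibition, with Mus musculus as the target, with stated times of 30 min, 10 min and 20 min; a lower number here means that less compound is needed, a higher number that more compound is needed for the effect. Compound 1 `Cc1ccc(N2CCN(CC(=O)N(c3ccccc3)c3ccccc3)CC2)cc1` gives 31.2 mg/kg. Among the compounds with values here, compound 2 therefore stands lowest of the two numbers so far, and the only step between measured compounds, a 2.5-fold lower number from compound 1 to compound 2 (0.39 log units; beyond the scatter), is modest but beyond the scatter. Compound 3 `O=C(CN1CCN(c2ccc(Cl)c(Cl)c2)CC1)N(c1ccccc1)c1ccccc1` is not yet measured; it differs from compound 2 by 3,4-dichlorophenyl in place of 2-methoxyphenyl on an amine nitrogen in a ring. The step from compound 1 to compound 2 is the only one that touches the same position, the aryl on the ring nitrogen, and it shows that such a swap can move the dose in this assay by a modest amount. Within the data shown here, no measured step involves the 3,4-dichlorophenyl group itself, so the direction for compound 3 cannot be read from the two numbers; the size is expected to be of the same modest order. Compound 3 is estimated at 18 mg/kg in this assay, with a range from 7 mg/kg to 45 mg/kg, which corresponds to an expected step of a 1.4-fold higher number from compound 2 to compound 3 (0.15 log units; within the scatter).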

Compound 3, dose for half-maximal effect: > 20 mg/kg
Compound 3 gave a limit, no number (the forecaster's own chance of this, stated with the estimate: 5%); middle value at least 1.1-fold (0.04 log units) from the limit.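

In this assay compound 3 gives a limit and not a number: the limit of > 20 mg/kg in this assay, at which 1 of the 3 values shown sits. Replacing 2-methoxyphenyl with 3,4-dichlorophenyl on the amine nitrogen in the ring gives an at least 1.5-fold higher number from compound 2 to compound 3 (0.19 log units; that floor lies within the scatter), so this swap at the position does not yet separate the two compounds by more than the usual spread of repeat measurements. The new information is that an aryl change here can yield a limit rather than a dose, leaving the series with two numbers and one limit, and the step involving compound 1 and compound 3 cannot be read.

Still open, from the compounds shown here alone, is what a 4-methoxyphenyl or a 3-chlorophenyl group would give on the same nitrogen, and whether a true number for compound 3 would lie clear of the value for compound 2. Going by these compounds, all three compounds share the rest of the core, so the outcome of a change elsewhere, such as a carboxylic acid on one of the other phenyl groups or a longer chain in place of the link to the carbonyl, also remains open.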